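A few compounds are considered here, and "the series" means these few. Any claim that something is new, unique, unknown or untested is made for them only; others in the source may bear on it.

In an ADME assay on HL-60 cells (Homo sapiens) for cytotoxicity, read by MTT assay, with a stated time of 24 h (on this read-out higher numbers stand for weaker inhibition and lower numbers for stronger inhibition), compound 1 (`CN1CCC=C(c2ccc(CN(C)Cc3ccccc3)cc2)C1`) gives > 50000 nM, a limit of the assay and not a number. Compound 2 (`COc1ccc(CN(C)Cc2ccc(C3=CCCN(C)C3)cc2)cc1`) gives > 50000 nM, likewise only a limit. Among the compounds with values here, the series so far stands at the limit of > 50000 nM in this assay, at which 2 of the 2 values shown sit. Within the data shown here, the one measured step, a step that the two limits leave unreadable from compound 1 to compound 2, is the only one bearing on compound 3 (`CN1CCC=C(c2ccc(CN(C)Cc3ccc([N+](=O)[O-])cc3)cc2)C1`), and it offers no size to carry over. Compound 3 differs by nitro in place of methoxy on an aromatic carbon, para to a large group. No step beyond the scatter is expected, and no direction can be named. The expected step is a number no higher from compound 2 to compound 3 (the limit leaves the size open). Compound 3 is estimated at 50000 nM, with a range of 15000 nM to 100000 nM.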

Compound 3, half-maximal inhibitory concentration: 28000 nM
The estimate for compound 3 lay 1.8-fold (0.25 log units) above the measured number, within the range that was stated.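

In this assay, within the data shown here, nitro on an aromatic carbon para to a large group gives the first number rather than a limit, so a change at this position can now be partly read. Against methoxy the change is an at least 1.7-fold lower number from compound 2 to compound 3 (0.25 log units; that floor lies within the scatter), and against hydrogen it is an at least 1.7-fold lower number from compound 1 to compound 3 (0.25 log units; that floor lies within the scatter). The step from compound 1 to compound 2 cannot be read, and two values remain limits: the limit of > 50000 nM in this assay, at which 2 of the 3 values shown sit.

On these data alone, the true size of both readable steps stays open. So does whether an amine or a carboxylic acid on this carbon would also give a number rather than a limit.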